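Swapping the aryl group on an amine nitrogen

A few compounds are considered here, and "the series" means these few. Any claim that something is new, unique, unknown or untested is made for them only; others in the source may bear on it.

Compound 1 `C[C@@H](Cn1ccc(-c2ccc(C#N)c(Cl)c2)n1)NC(=O)c1ccccc1F` gives 2190 nM
Compound 2 `C[C@@H](Cn1ccc(-c2ccc(C#N)c(Cl)c2)n1)Nc1cccnc1` gives > 30000 nM

In a functional assay on VCaP cells (Homo sapiens) for antiproliferative activity, read by CCK-8 assay, with a stated time of 6 days (a higher number here means a weaker inhibitor, a lower number a stronger inhibitor), compound 2 sits at > 30000 nM as a limit of the assay, not a number. Compound 3 `Cc1ccnc(N[C@@H](C)Cn2ccc(-c3ccc(C#N)c(Cl)c3)n2)n1` differs from it by 4-methylpyrimidin-2-yl in place of pyridin-3-yl on an amine nitrogen with 4-methylpyrimidin-2-yl in place of pyridin-3-yl on an amine nitrogen. Within the data shown here, the one measured step at this nitrogen is an at least 13-fold higher number from compound 1 to compound 2 (1.13 log units; beyond the scatter) and it is large, but no measured step exchanges one ring for another there. In this assay only a modest move towards a lower number is expected, the estimated step being an at least 1.5-fold lower number from compound 2 to compound 3 (0.17 log units; that floor lies within the scatter) and no more. For compound 3 the estimated value is 20000 nM with an expected range of 6000 nM to 30000 nM overall.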

Compound 3, half-maximal inhibitory concentration: 850 nM
Estimate against measurement, compound 3: 24-fold (1.37 log units) above, outside the stated range (below it).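

In this assay, exchanging one ring for another at this amine nitrogen proves able to carry a large step: an at least 35-fold lower number from compound 2 to compound 3 (1.54 log units; beyond the scatter). The value of compound 2 is a limit of the assay, not a number: the limit of > 30000 nM in this assay, at which 1 of the 3 values shown sits. A carbonyl on this nitrogen is not needed for a lower number, with a 2.6-fold lower number from compound 1 to compound 3 (0.41 log units; beyond the scatter).

On these data alone, the methyl group and the added ring nitrogen enter together, so the share of each in the step stays open. Also open, as far as these compounds go, is whether an unsubstituted pyrimidin-2-yl or a 4-methoxypyrimidin-2-yl group would hold the value of compound 3.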